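The source may report more compounds than this note shows. Statements on the series, on what has been measured and on what is new or still open speak of the compounds shown alone.

Measured so far in a functional assay on HepG2 cells (Homo sapiens) for inhibition, read by MTT assay, with a stated time of 3 days (on this read-out lower numbers stand for stronger inhibition and higher numbers for weaker inhibition), are two compounds:
- compound 1 `CCOC(=O)CN(C)CC(=O)NNC(=O)COc1ccc(-c2nc3ccccc3s2)cc1OC` gives 3180 nM
- compound 2 `CCOC(=O)[C@@H](NCC(=O)NNC(=O)COc1ccc(-c2nc3ccccc3s2)cc1OC)[C@@H](C)CC` gives 3460 nM

Compound 2 stands level with compound 1 in this assay and the two cannot be told apart. Compound 3 `CCOC(=O)[C@H](NCC(=O)NNC(=O)COc1ccc(-c2nc3ccccc3s2)cc1OC)[C@@H](C)CC` has the same atoms and bonds as compound 2 and differs only in configuration as drawn (the two compounds have the same atoms and bonds and differ only in configuration as drawn: 1 of 2 stereo elements differ; a stereocentre at a saturated chain carbon is drawn S in compound 2 and R in compound 3). Within the data shown here, no measured pair tests a change of configuration. Among the measured compounds shown here, the one measured step (a 1.1-fold higher number from compound 1 to compound 2 (0.04 log units; within the scatter)) replaced ((ethoxycarbonyl)methyl)(methyl)amino by (1-(ethoxycarbonyl)-2-methylbutyl)amino and stayed within the scatter. It therefore gives only weak support for expecting no step beyond the scatter here, in either direction. The estimated step is accordingly small (a 1.0-fold lower number from compound 2 to compound 3 (0.01 log units; within the scatter)). Compound 3 is expected at 3400 nM (estimated range 1600 nM to 7200 nM).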

Compound 3, half-maximal inhibitory concentration: 3970 nM
For compound 3 the middle estimate is 1.2-fold (0.07 log units) below the measured one; measured number inside the range.
By their numbers in this assay, from the lowest: compounds 1, 2 and 3 (each within the scatter of the next).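

In this assay, among these compounds, switching the stereocentre at the saturated chain carbon from S to R gave a 1.1-fold higher number from compound 2 to compound 3 (0.06 log units; within the scatter), so the configuration at this carbon, tested here for the first time, produced no step beyond the scatter. The (1-(ethoxycarbonyl)-2-methylbutyl)amino group in place of ((ethoxycarbonyl)methyl)(methyl)amino also stayed within the scatter with the R drawing, at a 1.2-fold higher number from compound 1 to compound 3 (0.10 log units; within the scatter), so the earlier result for this replacement holds for both drawn configurations. The comparison of the two stereoisomers rests on a single change: the fact that compounds 2 and 3 differ only in the configuration as drawn

The compounds shown leave open whether the other stereocentre, drawn alike in compound 2 and compound 3, has any bearing on the number in this assay. They also leave open whether a carboxylic acid in place of the ethyl ester would give a step beyond the scatter.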